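This account rests on a few compounds, and the source may have more. Where it says the series, first, only, none or still open, it means among the compounds named here.

In a functional assay on THP-1 cells (Homo sapiens) for cytotoxicity, read by MTT assay, with a stated time of 24 h (a higher number here means a weaker inhibitor, a lower number a stronger inhibitor), compound 1, `CCCCCCCCCCn1cc(Cn2nc(N)c3c(C(F)(F)F)cc(-c4ccccc4)nc32)nn1`, gives 48.7 ug/mL. Going by the values given here, that is the higher of the two values measured so far; its only neighbour is compound 2, `Nc1nn(Cc2cn(CC(=O)Nc3cccc(Cl)c3)nn2)c2nc(-c3ccccc3)cc(C(F)(F)F)c12`, which gives 37 ug/mL, and the step of a 1.3-fold lower number from compound 1 to compound 2 (0.12 log units; within the scatter) is too small to count as a real difference. That step replaces the same group at the same place as the one now considered: (3-chlorophenyl)carbamoyl in place of nonyl on a saturated chain carbon bound to an aromatic nitrogen.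

Compound 3, `Nc1nn(Cc2cn(CC(=O)Nc3c(F)cccc3F)nn2)c2nc(-c3ccccc3)cc(C(F)(F)F)c12`, has not yet been measured in this assay. Its change from compound 1 is (2,6-difluorophenyl)carbamoyl in place of nonyl on a saturated chain carbon bound to an aromatic nitrogen. Among the compounds with values here, the only measured step that bears on it, the one from compound 1 to compound 2, lies within the scatter, so a (2,6-difluorophenyl)carbamoyl entering in place of nonyl is expected to leave the number near where compound 1 sits, with no step beyond the scatter in either direction. Compound 3 is therefore expected to give about 42 ug/mL, within a range from 22 ug/mL to 80 ug/mL. That estimate means an expected step of a 1.2-fold lower number from compound 1 to compound 3 (0.06 log units; within the scatter).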

Compound 3, half-maximal inhibitory concentration: 43.3 ug/mL
Compound 3: the middle estimate sits 1.0-fold (0.01 log units) below what was measured; the range from low to high includes it.
By their numbers in this assay, from the lowest: compounds 2, 3 and 1 (each within the scatter of the next).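

With (2,6-difluorophenyl)carbamoyl in place of nonyl on a saturated chain carbon bound to an aromatic nitrogen, this assay gives a 1.1-fold lower number from compound 1 to compound 3 (0.05 log units; within the scatter), so a second carbamoyl group bearing a different ring also cannot be told apart from the long chain. Going by these compounds alone, compound 2 and compound 3 differ only in the ring on the amide-type nitrogen, and 2,6-difluorophenyl in place of 3-chlorophenyl gives a 1.2-fold higher number from compound 2 to compound 3 (0.07 log units; within the scatter), which offers the first direct comparison of two rings there and shows no readable difference between them. Across these three compounds, neither replacing the chain with a carbamoyl group nor changing the ring on it separates the numbers, and no measurement at hand speaks to why they read alike.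

On these data alone, whether a carboxylic acid or an amine at this position, or an unsubstituted phenyl on the amide-type nitrogen, would move the number beyond the scatter remains open. As far as these compounds go, all three compounds also share the same core, so the effect of a change elsewhere in it is open too.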